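A few compounds are considered here, and "the series" means these few. Any claim that something is new, unique, unknown or untested is made for them only; others in the source may bear on it.

Series notes, growth inhibition of a breast-cancer line.

Compound 1 `CNC(=O)/C=C/c1ccncc1-c1ccc2cc[nH]c2c1` is the reference amide. In a functional assay on MDA-MB-231 cells (Homo sapiens) for inhibition, read by sulforhodamine B assay, with a stated time of 72 h (on this read-out lower numbers stand for stronger inhibition of growth and higher numbers for weaker inhibition of growth), compound 1 gives 7680 nM. Compound 2 `O=C(O)/C=C/c1ccncc1-c1ccc2cc[nH]c2c1` carries the change (hydroxy in place of methylamino on a carbonyl carbon). In this assay compound 2 reaches only the limit > 10000 nM, so the step of an at least 1.3-fold higher number from compound 1 to compound 2 (0.11 log units; that floor lies within the scatter) is a floor rather than a measured number.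

Compound 3 `CNC(=O)/C=C/c1ccncc1-c1ccc2[nH]ccc2c1` has the same atoms as compound 1 joined differently; how the two cores differ is not broken down here. In this assay compound 3 sits at the limit > 10000 nM.

Compound 4 `O=C(O)/C=C/c1ccncc1-c1ccc2[nH]ccc2c1` is not yet measured. It relates to compound 3 by hydroxy in place of methylamino on a carbonyl carbon, the same change that leads from compound 1 to compound 2, made at the same place. The earlier step could only be read as a floor because of the limit of > 10000 nM in this assay, at which 2 of the 3 values shown sit, and compound 3 already stands at that limit, so compound 4 is expected to give at most a step that the limit leaves unreadable from compound 3 to compound 4, most likely returning another limit. The estimate for compound 4 in this assay is 20000 nM, between 10000 nM and 60000 nM.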

Compound 4, concentration for 50% growth inhibition: > 10000 nM
Compound 4 gave a limit, no number (the forecaster's own chance of this, stated with the estimate: 85%); the middle value is on the limit's open side.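

Compound 3 and compound 4 both stand at a limit in this assay, so no step between them can be read: the limit of > 10000 nM in this assay, at which 3 of the 4 values shown sit.

The compounds shown leave open how much growth inhibition compound 2, compound 3 and compound 4 actually give, and whether hydroxy in place of methylamino has the same size of effect on both cores.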